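Working notes: chloro to bromo in the series

The compounds below may be only part of what the source reports. "The series", "measured", "known", "first", "only" and "open" are said of these compounds alone.

Values in a functional assay on MT4 cells (Homo sapiens) for cytotoxicity; on this read-out higher numbers stand for weaker inhibition and lower numbers for stronger inhibition:
- Compound 1 `COc1cccc(Sc2cccc(N)c2C#N)c1`: > 200000 nM (a limit)
- Compound 2 `N#Cc1c(N)cccc1Sc1cccc(Cl)c1`: 53000 nM
- Compound 3 `N#Cc1c(N)cccc1Sc1cccc(Br)c1`: not yet measured

Within the data shown here, compound 2 holds the only actual number so far, 53000 nM. The reading for compound 1 is a limit of the assay, > 200000 nM.

The change under review is bromo in place of chloro on an aromatic carbon. Among the measured compounds shown here, the only measured step is an at least 3.7-fold lower number from compound 1 to compound 2 (0.57 log units; beyond the scatter), with chloro in place of methoxy on an aromatic carbon. On these data alone, its true size remains open because of the limit of > 200000 nM in this assay, at which 1 of the 2 values shown sits. That step bears only indirectly on the new change, since it replaces methoxy and not one halogen with another. For the measured compounds named here, the series offers no measured step between two halogens.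

The expectation therefore rests on compound 2 at 53000 nM, and no step beyond the scatter is expected in this assay. The estimated step is a 1.2-fold lower number from compound 2 to compound 3 (0.07 log units; within the scatter). Compound 3 is estimated at 45000 nM. The expected range for compound 3 runs from 18000 nM to 110000 nM.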

Compound 3, half-maximal inhibitory concentration: 53000 nM
Compound 3: the middle estimate sits 1.2-fold (0.07 log units) below what was measured, and the stated range covers the measured number.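

In this assay the series now holds its first measured step between two halogens, and that step shows no change at the digits printed from compound 2 to compound 3 (within the scatter). On an aromatic carbon meta to a large group, chloro and bromo therefore cannot be told apart on this read-out, something the earlier step from methoxy to chloro could not show. On these data alone, the step with bromo in place of methoxy is an at least 3.7-fold lower number from compound 1 to compound 3 (0.57 log units; beyond the scatter), so bromo, like chloro, separates from methoxy on this read-out, and the true size of that separation stays open: the limit of > 200000 nM in this assay, at which 1 of the 3 values shown sits.

Fluoro, an amine and a carboxylic acid at this same carbon remain open, so the compounds shown do not tell whether the match between chloro and bromo extends beyond these two halogens. Also open is whether chloro and bromo would match on another carbon of this six-membered aromatic ring, since the compounds shown vary only this one place on the shared core.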